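Compound 4: fluoro in place of phenyl

This account rests on a few compounds, and the source may have more. Where it says the series, first, only, none or still open, it means among the compounds named here.

In a functional assay on HL-60 cells (Homo sapiens) for cytotoxicity, read by luminescence and CellTiter-Glo, with a stated time of 3 days (on this read-out higher numbers stand for weaker inhibition and lower numbers for stronger inhibition), compound 2 `O=C(Nc1cc(C(F)(F)F)cc(C(F)(F)F)c1)c1cc(Br)c(-c2ccccc2)cc1O` gives 430 nM. Compound 1 `O=C(Nc1cc(C(F)(F)F)cc(C(F)(F)F)c1)c1cc(Cl)c(F)cc1O` gives 430 nM, level with compound 2 at these digits, and the two share the lowest of the three numbers. Compound 3 `O=C(Nc1cc(C(F)(F)F)cc(C(F)(F)F)c1)c1ccc(-c2ccccc2)cc1O` gives 1140 nM. Going by the values given here, the one measured step is a 2.7-fold higher number from compound 2 to compound 3 (0.42 log units; beyond the scatter), modest and beyond the scatter, with hydrogen in place of bromo.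

Compound 4 `O=C(Nc1cc(C(F)(F)F)cc(C(F)(F)F)c1)c1cc(Br)c(F)cc1O` keeps the bromo of compound 2 and changes the other group: fluoro in place of phenyl on an aromatic carbon. Among the compounds with values here, no measured step covers the loss of the phenyl directly, so the step from compound 2 to compound 3 bears on this change only loosely. The closer guide is the fluoro group shared with compound 1. Compound 4 holds bromo where compound 1 holds chloro, and compound 1 gives 430 nM. In this assay the expected step is a 1.0-fold higher number from compound 2 to compound 4 (0.02 log units; within the scatter), with no change beyond the scatter anticipated. Compound 4 is estimated at 450 nM, with an expected range of 200 nM to 1000 nM.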

Compound 4, half-maximal inhibitory concentration: 250 nM
Estimate against measurement, compound 4: 1.8-fold (0.26 log units) above; the range from low to high includes it.
By their numbers in this assay, from the lowest: compounds 4, 1 and 2 (each within the scatter of the next); then compound 3.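

In this assay, the aromatic carbon ortho to the bromo group accepts either phenyl or fluoro: a 1.7-fold lower number from compound 2 to compound 4 (0.24 log units; within the scatter) is within the scatter, so the phenyl group is not required for a number in this range, and the two groups cannot be told apart here. The halogen comparison gives the same kind of result, with a 1.7-fold lower number from compound 1 to compound 4 (0.24 log units; within the scatter) also within the scatter, so bromo and chloro are not separated when fluoro is present. No measurement here bears on why these compounds read as they do.

Open, going by these compounds, is whether an amine or a carboxylic acid on the same carbon would stay within this range. Going by these compounds alone, also open is whether hydrogen in place of bromo with fluoro present would repeat a 2.7-fold higher number from compound 2 to compound 3 (0.42 log units; beyond the scatter), a step so far seen only with phenyl.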